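The source may hold more compounds than are shown below. What is called first, only, known or untested is meant among the compounds shown, and "the series" means these compounds.

In a functional assay on HEY cells (Homo sapiens) for cytotoxicity, read by MTT assay, with a stated time of 72 h (on this read-out lower numbers stand for stronger inhibition and higher numbers for weaker inhibition), compound 1 `COc1cccc(CNC(=O)c2nc(Br)c3cccnc3c2N[C@H]2CC[C@H](N)CC2)c1` gives 7000 nM, the second highest of the three numbers recorded. Compound 2 `N[C@H]1CC[C@H](Nc2c(C(=O)NCc3cccc(C(F)(F)F)c3)nc(Br)c3cccnc23)CC1` gives 12000 nM, and compound 3 `CN(C)c1ccc(CNC(=O)c2nc(Br)c3cccnc3c2N[C@H]2CC[C@H](N)CC2)cc1` gives 5300 nM. Compound 4 `C[C@H](NC(=O)c1nc(Br)c2cccnc2c1N[C@H]1CC[C@H](N)CC1)c1ccc(F)cc1` has not yet been measured; it differs from compound 1 by 1-(4-fluorophenyl)ethyl in place of 3-methoxybenzyl on an amide-type nitrogen. Three measured steps swap the same group on the amide-type nitrogen: a 1.7-fold higher number from compound 1 to compound 2 (0.23 log units; within the scatter), a 1.3-fold lower number from compound 1 to compound 3 (0.12 log units; within the scatter) and a 2.3-fold lower number from compound 2 to compound 3 (0.35 log units; beyond the scatter). Each of those swaps moved this assay only a little, so another swap at the same place is expected to leave the number close to that of compound 1. Compound 4 is therefore estimated at 7000 nM, with a range from 3000 nM to 16000 nM, an expected step of no change at the digits printed from compound 1 to compound 4 (within the scatter).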

Compound 4, half-maximal inhibitory concentration: > 10000 nM
Compound 4 ended at the assay's limit; the forecaster's own chance of this, stated with the estimate: 5%; middle value at least 1.4-fold (0.15 log units) from the limit.
By their numbers in this assay, from the lowest: compounds 3, 1 and 2 (each within the scatter of the next, the first and the last beyond it).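

Compound 4 ended at a limit rather than a number: the limit of > 10000 nM in this assay, at which 1 of the 4 values shown sits. Its group, the first at this place with a defined stereocentre, gives an at least 1.4-fold higher number from compound 1 to compound 4 (0.15 log units; that floor lies within the scatter) and an at least 1.8-fold higher number from compound 3 to compound 4 (0.27 log units; that floor lies within the scatter); both are only floors, and the step from compound 2 cannot be read. So the amide-type nitrogen has not yet yielded a lower number with this group, though the size of the loss remains unknown.

A plain 4-fluorobenzyl group would help separate the contribution of the fluorine from that of the added methyl. The mirror-image 1-(4-fluorophenyl)ethyl group would test the stereocentre.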